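The compounds below may be only part of what the source reports. "The series", "measured", "known", "first", "only" and "open" are said of these compounds alone.

Measured in a functional assay on MCF7 cells (Homo sapiens) for antiproliferative activity, read by sulforhodamine B assay, with a stated time of 3 days; a lower number here means a stronger inhibitor, a higher number a weaker inhibitor:

- Compound 1 `O=c1ccn(C2COc3ccccc3CO2)c(=O)[nH]1` gives 5000 nM
- Compound 2 `c1ccc(Sc2ncnc3c2ncn3C2COc3ccccc3CO2)cc1` gives 7120 nM
- Compound 3 `Clc1ccc(Sc2ncnc3ncn(C4COc5ccccc5CO4)c23)c(Cl)c1` gives 8400 nM

These three compounds sit close together. Compound 3, at 8400 nM in this assay, lies within the usual scatter of both other compounds, so the numbers set none of them apart. Within the data shown here, the series offers no pair of measured compounds that differ in one place only, which leaves no measured step to serve as a direct guide.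

The next compound is compound 4 `Fc1ccc(Sc2ncnc3ncn(C4COc5ccccc5CO4)c23)cc1`, which carries 4-fluorophenyl in place of 2,4-dichlorophenyl on a sulfur, a change counted as 4-fluorophenyl in place of 2,4-dichlorophenyl on a sulfur in full.

The nearest evidence is modest. Compound 2 at 7120 nM and compound 3 at 8400 nM fall within the scatter of each other, and all three measured values occupy a narrow band. On that basis, no step beyond the scatter is expected in this assay, in either direction. The estimated change is a 1.2-fold lower number from compound 3 to compound 4 (0.08 log units; within the scatter) and it is expected to remain within the scatter. Compound 4 is expected to give an estimated 7000 nM in this assay, with an expected range from 3500 nM to 14000 nM as its bounds.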

Compound 4, half-maximal inhibitory concentration: 14100 nM
Compound 4: the middle estimate sits 2.0-fold (0.30 log units) below what was measured; measured number above the stated range.
By their numbers in this assay, from the lowest: compounds 1, 2, 3 and 4 (each within the scatter of the next, the first and the last beyond it).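

In this assay, among these compounds, putting 4-fluorophenyl in place of 2,4-dichlorophenyl on a sulfur gives the first measured step between compounds that differ in one place, a 1.7-fold higher number from compound 3 to compound 4 (0.22 log units; within the scatter), and so provides the direct comparison that the earlier compounds lacked. At this position, then, the exchange of one halogen-bearing phenyl group for the other, with both chlorines gone and a fluorine in their place, does not separate the two compounds in this read-out, and the sulfur-linked phenyl ring tolerates this change without a step beyond the scatter. The compounds shown offer no measurement that would account for the size of this step or tie it to any property of either group.

As far as these compounds go, what remains open is whether this position can produce a step beyond the scatter at all, since a single exchange between two halogen-bearing phenyl groups samples only a narrow part of what could sit on the sulfur. An amine or a carboxylic acid on the phenyl ring, or a longer alkyl chain in place of the ring, would test that question directly.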